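The source may report more compounds than this note shows. Statements on the series, on what has been measured and on what is new or still open speak of the compounds shown alone.

Compound 1, `COc1ccccc1N1CCN(CC2=NS(=O)(=O)c3ccccc3N2)CC1`, carries a methoxyphenylpiperazine linked through a methylene to a fused sulfonamide-bearing ring system. In a functional assay on thoracic aorta for antagonist activity at Alpha-1D adrenergic receptor (Rattus norvegicus) (on this read-out higher numbers stand for higher potency (the scale is a negative logarithm) and lower numbers for lower potency), compound 1 gives 7.59. Compound 2, `COc1ccccc1N1CCN(CC2=NS(=O)(=O)c3ccc(C)cc3N2)CC1`, differs from it by a single change: methyl in place of hydrogen on an aromatic carbon. In this assay compound 2 gives 5.5, and the step of a number 2.09 log units lower from compound 1 to compound 2 (beyond the scatter) is a large fall for so small a change.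

Compound 3, `COc1ccccc1N1CCN(CC2Nc3ccccc3S(=O)(=O)N2)CC1`, shares the methoxyphenylpiperazine and the methylene linker but is built on a different core; the difference between the two cores is not broken down here. In this assay compound 3 gives 5.34. Against compound 2 its value lies within the usual scatter, so no order between the two can be stated; against compound 1 it lies well below.

Compound 4, `COc1ccccc1N1CCN(CC2Nc3cc(C)ccc3S(=O)(=O)N2)CC1`, has not yet been measured. It stands to compound 3 as compound 2 stands to compound 1: methyl in place of hydrogen on an aromatic carbon. The place description is the same word for word, so this is the same change made on the other core. If the change behaves on the core of compound 3 as it did on the core of compound 1, compound 4 would be expected to fall by roughly the step seen from compound 1 to compound 2; yet compound 3 starts low, at 5.34, and a fall of that size would carry compound 4 well below any value seen among these three compounds. On that basis a smaller step is estimated, a number 0.54 log units lower from compound 3 to compound 4 (beyond the scatter), giving an expected value for compound 4 of 4.8, within a range of 4.2 to 5.5.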

Compound 4, negative logarithm of the antagonist equilibrium constant: 5.98
Compound 4: the middle estimate sits 1.18 log units below what was measured; the measured number lies above the stated range.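

In this assay, methyl in place of hydrogen on an aromatic carbon gives a number 0.64 log units higher from compound 3 to compound 4 (beyond the scatter), so the change keeps neither its direction nor its size when it is carried from one core to the other: the same change on two cores in this assay, a number 2.09 log units lower (beyond the scatter) from compound 1 to compound 2 and a number 0.64 log units higher (beyond the scatter) from compound 3 to compound 4, 2.73 log units apart, beyond the scatter of two such steps. Within this series, then, the outcome of the change depends on the core that carries it, and the step measured on the core of compound 1 could not be transferred as a number to the core of compound 3. This does not show which feature of the two cores separates the results, and two pairs set no rule for what the same change would do on any further core.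

The compounds shown leave open whether the opposite steps belong to methyl alone or would also appear with another group in its place, such as an ethyl group or a chlorine atom, on the same aromatic carbon of each core. They also leave open what a methyl group would do on the other aromatic carbons of the two cores, since each core is shown with only one such change.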